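This account rests on a few compounds, and the source may have more. Where it says the series, first, only, none or still open, it means among the compounds named here.

Compound 1 `CCOc1ccccc1OCCSC(=S)N[C@H]1CCOC1=O` stands apart from the pair under study. In a functional assay on MGC-803 cells (Homo sapiens) for antiproliferative activity, read by MTT assay, with a stated time of 72 h (on this read-out higher numbers stand for weaker inhibition and lower numbers for stronger inhibition), compound 1 gives only a limit, > 64000 nM. Among the measured compounds shown here, compound 2 `O=C(COc1ccc(C(=O)/C=C/c2cccc(Br)c2)cc1)N[C@H]1CCOC1=O` holds the only measured number in the set: in this assay compound 2 gives 11900 nM. Compound 3 `O=C(COc1ccc(C(=O)/C=C/c2cccc([N+](=O)[O-])c2)cc1)N[C@H]1CCOC1=O` differs from compound 2 in one place: nitro in place of bromo on an aromatic carbon. No measured pair of this kind exists among the shown compounds, so the size of the step in this assay is open; a change within the usual scatter, or a modest gain, is expected. The expected step is a 1.3-fold lower number from compound 2 to compound 3 (0.12 log units; within the scatter). For compound 3 the estimate is 9000 nM, ranging from 3000 nM to 25000 nM.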

Compound 3, half-maximal inhibitory concentration: > 64000 nM
Compound 3 was reported as a limit; the forecaster's own chance of this, stated with the estimate: 5%; at least 7.1-fold (0.85 log units) between middle value and limit.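

In this assay, among the compounds shown here, the first one-place comparison shows an at least 5.3-fold higher number from compound 2 to compound 3 (0.73 log units; beyond the scatter) for 3-bromophenyl to 3-nitrophenyl, so this place on the aromatic ring does not accept every replacement of bromo. Compound 3 gives a limit and not a number, so the step is a lower bound only: the limit of > 64000 nM in this assay, at which 2 of the 3 values shown sit.

Still open, from the compounds shown here alone, is whether this loss is specific to nitro or follows from removing bromo at all. Chloro, methoxy or an amine at this place would separate these readings, as would hydrogen.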